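The source may report more compounds than this note shows. Statements on the series, on what has been measured and on what is new or still open speak of the compounds shown alone.

Measured in a functional assay on MCF7 cells (Homo sapiens) for antiproliferative activity, read by MTT assay, with a stated time of 48 h; a lower number here means a stronger inhibitor, a higher number a weaker inhibitor:
- compound 1 `Clc1ccc2[nH]c(-c3cn(-c4ccccc4)nc3-c3ccccc3)nc2c1`: 1960 nM
- compound 2 `Clc1ccc(-c2nn(-c3ccccc3)cc2-c2nc3cc(Cl)ccc3[nH]2)cc1`: 1170 nM
- compound 3 `COc1ccc(-c2nn(-c3ccccc3)cc2-c2nc3cc(F)ccc3[nH]2)cc1`: 1510 nM

Compound 3 lies within the scatter of both compound 1 and compound 2, so these values do not separate the three compounds. The next compound is compound 4 `COc1ccc(-c2nn(-c3ccccc3)cc2-c2nc3cc(Cl)ccc3[nH]2)cc1`, and the change is chloro in place of fluoro on an aromatic carbon.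

Going by the values given here, no measured step makes this exchange. The nearest evidence is a different exchange, chloro in place of hydrogen on an aromatic carbon: a 1.7-fold lower number from compound 1 to compound 2 (0.22 log units; within the scatter). That step stays within the scatter. Among the compounds with values here, compound 1 and compound 2 both carry the chloro that enters compound 4, but no measured pair shows what replacing fluoro with it does. No step beyond the scatter is therefore expected in this assay, and no firm direction can be assigned. The expected step is a 1.2-fold lower number from compound 3 to compound 4 (0.07 log units; within the scatter). The estimate for compound 4 is 1300 nM, with an expected range of 700 nM to 2400 nM.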

Compound 4, half-maximal inhibitory concentration: 1760 nM
Estimate against measurement, compound 4: 1.4-fold (0.13 log units) below; the measured number falls inside the stated range.
By their numbers in this assay, from the lowest: compounds 2, 3, 4 and 1 (each within the scatter of the next).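

In this assay, the exchange of fluoro for chloro on the aromatic carbon, meta to a fused ring and para to a fused ring, now has a direct reading (a 1.2-fold higher number from compound 3 to compound 4 (0.07 log units; within the scatter)), and it stays within the scatter, so neither halogen separates from the other at this position. On an aromatic carbon, methoxy in place of chloro (a 1.5-fold higher number from compound 2 to compound 4 (0.18 log units; within the scatter)) and methoxy in place of hydrogen (a 1.1-fold lower number from compound 1 to compound 4 (0.05 log units; within the scatter)) also stay within the scatter, so every step now read in this small set remains unresolved. Nothing available speaks to the reason for these small steps.

From the compounds shown here alone, whether an amine or a carboxylic acid at this position would give a step beyond the scatter remains open. The same holds for a longer chain in place of the methoxy.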